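A few compounds are considered here, and "the series" means these few. Any claim that something is new, unique, unknown or untested is made for them only; others in the source may bear on it.

Measured so far:
Compound 1, `Cc1oc(-c2c(Cl)cccc2Cl)nc1CN1CCC(C(=O)NCCCN2C[C@H](C)C[C@H](C)C2)CC1`, gives 13200 nM in an ADME assay on Huh7.5.1 cells (Homo sapiens) for cytotoxicity, read by ATP content, with a stated time of 48 h; a lower number here means that less compound is tolerated, a higher number that more compound is tolerated.
Compound 2, `Cc1ccccc1-c1nc(CN2CCC(C(=O)NCCCCN3C[C@H](C)C[C@H](C)C3)CC2)c(C)o1`, gives 23100 nM in this assay.

Of these two numbers, compound 1 has the lower one, but compound 2 lies within the usual scatter of it, so the two readings cannot be told apart in a meaningful way. Compound 3, `Cc1cccc(C)c1-c1nc(CN2CCC(C(=O)NCCCN3C[C@H](C)C[C@H](C)C3)CC2)c(C)o1`, has not yet been measured. It differs from compound 1 in one place: 2,6-dimethylphenyl in place of 2,6-dichlorophenyl on an aromatic carbon. Going by the values given here, no pair of measured compounds differing in a single place is available, so there is no direct precedent for what this swap does in this assay. Among the compounds with values here, the only guidance is that the two measured compounds, which differ from each other elsewhere, fall within the scatter of one another, and that gives no sign of the number moving far. The step is therefore expected to be small, in either direction, and most likely within the scatter: a 1.1-fold higher number from compound 1 to compound 3 (0.06 log units; within the scatter). Compound 3 is estimated to give 15000 nM in this assay, with a range from 6000 nM to 38000 nM.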

Compound 3, half-maximal cytotoxic concentration: 21000 nM
Compound 3: middle estimate off by 1.4-fold (0.15 log units), on the low side; the measured number falls inside the stated range.
By their numbers in this assay, from the lowest: compounds 1, 3 and 2 (each within the scatter of the next).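

Going by these compounds alone, compound 1 and compound 3 form the first measured pair that differs in a single place, so swapping 2,6-dichlorophenyl for 2,6-dimethylphenyl on this aromatic carbon can now be read directly in this assay. The step is a 1.6-fold higher number from compound 1 to compound 3 (0.20 log units; within the scatter), so in this one pair the two readings cannot be told apart, even though the two chlorine atoms of the leaving group are exchanged for carbon atoms in the entering one. No supporting measurement is available to explain this outcome.

The compounds shown leave open whether other groups on this aromatic carbon, such as unsubstituted phenyl, 2,6-difluorophenyl or a pyridine ring, would also fall within the scatter of these two readings. Also open, going by these compounds, is whether the same swap would give a similar step in a compound that differs elsewhere, for example one with a longer chain or a carboxylic acid in place of the amide.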